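The source may report more compounds than this note shows. Statements on the series, on what has been measured and on what is new or still open speak of the compounds shown alone.

Measured compounds:
Compound 1, `NS(=O)(=O)c1ccc(N2N=C(c3ccc(OCc4ccccc4)cc3)CC2c2ccccc2Cl)cc1`, gives 26000 nM in an ADME assay on MT4 cells (Homo sapiens) for cytotoxicity, read by MTT assay, with a stated time of 96 h; on this read-out higher numbers stand for lower toxicity in this test and lower numbers for higher toxicity in this test.
Compound 2, `Cc1ccc(C2CC(c3ccc(OCc4ccccc4)cc3)=NN2c2ccc(S(N)(=O)=O)cc2)cc1`, gives 35000 nM.
Compound 3, `Cc1ccc(C2CC(c3ccc(Oc4ccccc4)cc3)=NN2c2ccc(S(N)(=O)=O)cc2)cc1`, gives 7200 nM.

Compound 4, `NS(=O)(=O)c1ccc(N2N=C(c3ccc(Oc4ccccc4)cc3)CC2c2ccccc2Cl)cc1`, has not yet been measured. Its core is that of compound 3, which differs from the core of compound 2 by phenyl in place of benzyl on an oxygen on an aromatic ring, and that change gave a 4.9-fold lower number from compound 2 to compound 3 (0.69 log units; beyond the scatter). The change from compound 3 to compound 4 is 2-chlorophenyl in place of 4-methylphenyl on a saturated ring carbon. The same change was already made once, from compound 2 to compound 1, as 2-chlorophenyl in place of 4-methylphenyl on a saturated ring carbon, and there it gave a 1.3-fold lower number from compound 2 to compound 1 (0.13 log units; within the scatter), a step within the scatter. Since the place of the change is described in the same words in both pairs, the same small step is expected here, so compound 4 is estimated at 6000 nM, a step of a 1.2-fold lower number from compound 3 to compound 4 (0.08 log units; within the scatter). This rests on one earlier pair only, so the range is kept wide, and compound 4 is expected to fall between an estimated low end of 2500 nM and an estimated high end of 15000 nM.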

Compound 4, half-maximal cytotoxic concentration: 40000 nM
Beside the measured number, compound 4's estimate is 6.7-fold (0.82 log units) below it; measured number outside the range, above it.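

In this assay, placing 2-chlorophenyl where 4-methylphenyl stood gives a 5.6-fold higher number from compound 3 to compound 4 (0.74 log units; beyond the scatter), so the size of this change on one core does not predict its size on the other: the same change on two cores in this assay, a 1.3-fold lower number (0.13 log units; within the scatter) from compound 2 to compound 1 and a 5.6-fold higher number (0.74 log units; beyond the scatter) from compound 3 to compound 4, 7.5-fold (0.87 log units) apart, beyond the scatter of two such steps. Placing phenyl where benzyl stood on the oxygen gives a 1.5-fold higher number from compound 1 to compound 4 (0.19 log units; within the scatter), and this change also differs between the two cores: the same change on two cores in this assay, a 4.9-fold lower number (0.69 log units; beyond the scatter) from compound 2 to compound 3 and a 1.5-fold higher number (0.19 log units; within the scatter) from compound 1 to compound 4, 7.5-fold (0.87 log units) apart, beyond the scatter of two such steps. These compounds show that the effects of the two changes do not simply add up, but they do not show why, and one set of four compounds gives no rule for the wider series. On these data alone, it remains open how this assay would respond to an unsubstituted phenyl or 4-methoxyphenyl on the saturated ring carbon, or to a longer chain such as 2-phenylethyl on the oxygen.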